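This account rests on a few compounds, and the source may have more. Where it says the series, first, only, none or still open, it means among the compounds named here.

Measured so far in an in vitro functional assay on cells (Fibroblast) for agonist activity at Alpha-1B adrenergic receptor (Homo sapiens); on this read-out higher numbers stand for an effect only at larger amounts of compound and lower numbers for an effect already at smaller amounts:
compound 1 `Cn1ncnc1-c1ccccc1NCC1=NCCN1` gives 39.8 nM.
compound 2 `Cn1nccc1-c1ccccc1NCC1=NCCN1` gives only a limit, < 100000 nM.
compound 3 `CCCn1nccc1-c1ccccc1NCC1=NCCN1` gives only a limit, < 100000 nM.

Compound 2 thus stands at the limit described by the limit of < 100000 nM in this assay, at which 2 of the 3 values shown sit, with no number of its own. The step that the limit leaves unreadable from compound 1 to compound 2 and the step that the two limits leave unreadable from compound 2 to compound 3 cannot be sized for that reason. Compound 4 `c1ccc(-c2cn[nH]c2)c(NCC2=NCCN2)c1` differs from compound 2 by 1H-pyrazol-4-yl in place of 1-methyl-1H-pyrazol-5-yl on an aromatic carbon. Going by the values given here, no measured step covers this change, and both steps that touch compound 2 are unreadable, so no size or direction is expected with any confidence for a step that the limit leaves unreadable from compound 2 to compound 4; the estimate is loose. Compound 4 is expected at 2000 nM, with a range from 50 nM to 80000 nM.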

Compound 4, half-maximal effective concentration: 79.4 nM
The estimate for compound 4 lay 25-fold (1.40 log units) above the measured number; the measured number falls inside the stated range.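

In this assay, the change to 1H-pyrazol-4-yl on this aromatic carbon gives a 2.0-fold higher number from compound 1 to compound 4 (0.30 log units; within the scatter). A pyrazolyl ring at this place can therefore carry a readable number, which compound 2 and compound 3 did not show. The steps touching compound 2 cannot be read because it has only a limit: the limit of < 100000 nM in this assay, at which 2 of the 4 values shown sit.

The change from compound 2 to compound 4 alters both the ring attachment and the N-methyl group, so the shown compounds do not separate the two. Going by these compounds, how 1-methyl-1H-pyrazol-4-yl, an amine or a carboxylic acid would read at this place remains open.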